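A Benzyl-to-Chlorophenyl Swap on an Aromatic Nitrogen

The source may hold more compounds than are shown below. What is called first, only, known or untested is meant among the compounds shown, and "the series" means these compounds.

Compound 1 `CCCCCc1ccc(C#Cc2c(-c3ccc(CCCCC)cc3)oc3nc(=O)n(Cc4cn(-c5ccc(Cl)cc5)nn4)cc23)cc1`: in a functional assay on HepG2 cells (Homo sapiens) for antiproliferative activity, read by MTT assay, with a stated time of 72 h (on this read-out higher numbers stand for weaker inhibition and lower numbers for stronger inhibition), compound 1 gives > 100000 nM, a limit of the assay rather than a number.
Compound 2 `CCCCCc1ccc(C#Cc2c(-c3ccc(CCCCC)cc3)oc3nc(=O)n(Cc4cn(Cc5ccccc5)nn4)cc23)cc1`: in this assay compound 2 gives > 100000 nM, again a limit.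
Compound 3 `O=c1nc2oc(CCCCl)cc2cn1Cc1cn(Cc2ccccc2)nn1`: in this assay compound 3 gives 27600 nM.

Compounds 1 and 2 share one core, while compound 3 carries another; the difference between the two cores is not broken down here. Within the first pair the change is 4-chlorophenyl in place of benzyl on an aromatic nitrogen, and the measured step is a step that the two limits leave unreadable from compound 2 to compound 1 because both values sit at the limit of > 100000 nM in this assay, at which 2 of the 3 values shown sit. Compound 4 `O=c1nc2oc(CCCCl)cc2cn1Cc1cn(-c2ccc(Cl)cc2)nn1` carries the same change on the core of compound 3, (4-chlorophenyl in place of benzyl on an aromatic nitrogen), at a place described in the same words. Since the earlier step gives no readable size, the expected step is small, a 1.1-fold higher number from compound 3 to compound 4 (0.04 log units; within the scatter). This expectation rests on compound 3 and its value of 27600 nM. Compound 4 is therefore estimated at 30000 nM, with a range from 10000 nM to 100000 nM.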

Compound 4, half-maximal inhibitory concentration: 89800 nM
The estimate for compound 4 lay 3.0-fold (0.48 log units) below the measured number; the measured number falls inside the stated range.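

In this assay, 4-chlorophenyl in place of benzyl on an aromatic nitrogen gives a 3.3-fold higher number from compound 3 to compound 4 (0.51 log units; beyond the scatter), so on this core the change weakens inhibition. The same change on the core of compound 1 cannot be read, because compound 1 and compound 2 both stand at a limit of the assay rather than at a number: the limit of > 100000 nM in this assay, at which 2 of the 4 values shown sit. The series therefore offers one readable step on one core, and it does not show whether the size of that step carries from one core to another.

The compounds shown leave open how a plain phenyl or a phenethyl group on that nitrogen would read. A plain phenyl would help separate the part played by the chlorine from that of the benzyl carbon link.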